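A methoxy group on two different cores

A few compounds are considered here, and "the series" means these few. Any claim that something is new, unique, unknown or untested is made for them only; others in the source may bear on it.

Three compounds share a bicyclic ketone core carrying an ether-linked heteroaromatic arm, and differ in the aromatic group at the end of that arm. Compound 1 `O=C1C[C@H](OCc2cn(Cc3ccccc3)nn2)[C@H]2CO[C@@H]1O2` carries a plain phenyl group. In a functional assay on MDA-MB-231 cells (Homo sapiens) for cytotoxicity, read by MTT assay, with a stated time of 48 h (a higher number here means a weaker inhibitor, a lower number a stronger inhibitor), compound 1 gives only a limit of the assay, > 50000 nM, not a number. Compound 2 `COc1ccc(Cn2cc(CO[C@H]3CC(=O)[C@@H]4OC[C@H]3O4)nn2)cc1` adds a methoxy group, the change (methoxy in place of hydrogen on an aromatic carbon), and in this assay compound 2 gives 34800 nM. The step of an at least 1.4-fold lower number from compound 1 to compound 2 (0.15 log units; that floor lies within the scatter) is recorded only as a floor because of the limit of > 50000 nM in this assay, at which 1 of the 3 values shown sits.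

Compound 3 `O=C1C[C@H](OCc2cc(/C=C/c3ccccc3)no2)[C@H]2CO[C@@H]1O2` has a different arm; how its core differs from that of compound 1 is not broken down here. In this assay compound 3 gives 22900 nM. Compound 4 `COc1ccc(/C=C/c2cc(CO[C@H]3CC(=O)[C@@H]4OC[C@H]3O4)on2)cc1` is made from compound 3 by the same change, (methoxy in place of hydrogen on an aromatic carbon), with the same surroundings. Since the step from compound 1 to compound 2 is at most modest, the step from compound 3 to compound 4 in this assay is expected to be small, a 1.3-fold lower number from compound 3 to compound 4 (0.10 log units; within the scatter). For compound 4 the expected value in this assay is 18000 nM, between 8000 nM and 45000 nM.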

Compound 4, half-maximal inhibitory concentration: 26400 nM
The estimate for compound 4 lay 1.5-fold (0.17 log units) below the measured number; the measured number falls inside the stated range.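

In this assay, going by these compounds alone, the change from phenyl to 4-methoxyphenyl gives a 1.2-fold higher number from compound 3 to compound 4 (0.06 log units; within the scatter), so on this second core the methoxy group leaves no step that can be told apart from the usual variation between repeated measurements. Set beside the step on the first core, the result does not settle whether the change behaves alike on both cores: the same change on two cores in this assay, an at least 1.4-fold lower number (0.15 log units; that floor lies within the scatter) from compound 1 to compound 2 and a 1.2-fold higher number (0.06 log units; within the scatter) from compound 3 to compound 4; the limit leaves it open whether they differ Neither step is shown to go beyond the scatter, but this does not prove that the change carries over unaltered, since compound 1 gives a limit rather than a number and a larger step on that core stays possible: the limit of > 50000 nM in this assay, at which 1 of the 4 values shown sits.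

Among the compounds shown, the methoxy group appears on the aromatic ring only para to a large group, so its effect elsewhere on that ring remains open. As far as these compounds go, it also remains open whether a different group at that place, such as an amine or a carboxylic acid, would shift the number beyond the scatter in this assay.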